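Chloro for Fluoro on the Benzoic Acid Ring

The source may report more compounds than this note shows. Statements on the series, on what has been measured and on what is new or still open speak of the compounds shown alone.

Compound 1, `Cc1cc(C(=O)O)ccc1OCCCCOc1ccc(C(=O)CC(C)C)c(O)c1C`: 42.1%
Compound 2, `Cc1c(OCCCCOc2ccc(C(=O)O)cc2Cl)ccc(C(=O)CC2CCCC2)c1O`: 27.4%
Compound 3, `Cc1c(OCCCCOc2ccc(C(=O)O)cc2F)ccc(C(=O)CC(C)C)c1O`: 67.7%

In an assay on HEK293 cells for positive allosteric modulation of metabotropic glutamate receptor 3 (Rattus norvegicus), read by thallium flux, with a stated time of 2.5 min (a higher number here means a larger maximal response, a lower number a smaller maximal response), compound 3 gives 67.7% and stands highest of the three measured compounds, beyond the scatter of both compound 1 and compound 2. For the measured compounds named here, the only measured single-point step is a number 25.6 percentage points higher from compound 1 to compound 3 (beyond the scatter), a modest gain. Compound 4, `Cc1c(OCCCCOc2ccc(C(=O)O)cc2Cl)ccc(C(=O)CC(C)C)c1O`, has not been measured; it differs from compound 3 as follows: chloro in place of fluoro on an aromatic carbon.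

Going by the values given here, no measured step swaps chloro for fluoro, so the bearing of a number 25.6 percentage points higher from compound 1 to compound 3 (beyond the scatter) is indirect: it shows only that a small halogen at this carbon is compatible with a higher maximal response than methyl. Among the compounds with values here, compound 2 carries the chloro group of compound 4 but also a different ketone side chain; in this assay compound 2 gives 27.4%, and no single step connects it to compound 4, so its value can only hint that chloro does not guarantee a high response. Compound 4 is therefore expected to give a maximal response somewhat lower than compound 3, with a number 17.7 percentage points lower from compound 3 to compound 4 (beyond the scatter) as the estimated step, and an estimate of 50%, in the range 30% to 72%.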

Compound 4, largest response reached (reported as percent of maximum), in percent of the reference or control that the assay uses: 62.9%
For compound 4 the middle estimate is 12.9 percentage points below the measured one, and the stated range covers the measured number.
By their numbers in this assay, from the lowest: compound 2; then compound 1; then compounds 4 and 3 (each within the scatter of the next).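

In this assay, chloro in place of fluoro on this aromatic carbon, ortho to a large group and meta to a carboxy group, gives a number 4.8 percentage points lower from compound 3 to compound 4 (within the scatter), so the two halogens cannot be told apart here. Chloro in place of methyl at the same carbon gives a number 20.8 percentage points higher from compound 1 to compound 4 (beyond the scatter), so chloro, like fluoro, stands clear of methyl. With chloro kept, isopropyl in place of cyclopentyl on the ketone side chain gives a number 35.5 percentage points higher from compound 2 to compound 4 (beyond the scatter), which shows that the low value of compound 2 cannot be laid on chloro alone.

From the compounds shown here alone, what a bromo or methoxy group would give at this carbon stays open, as does the effect of the cyclopentyl change with fluoro in place. Nothing shown accounts for these steps.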